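A few compounds are considered here, and "the series" means these few. Any claim that something is new, unique, unknown or untested is made for them only; others in the source may bear on it.

In an ADME assay on microsomes from liver (Mus musculus) for metabolic stability, read by mass spectrometry, with a stated time of 40 min, tested at 1 uM (on this read-out lower numbers stand for a less stable compound and higher numbers for a more stable compound), compound 1 (`COc1cc(N2CCN(Cc3ccccn3)CC2)ccc1Nc1nc(NC2CCCCC2)c2nc[nH]c2n1`) gives 38% and compound 2 (`COc1cc(N2CCC(C(=O)N3CCC(N(C)C)C3)CC2)ccc1Nc1nc(NC2CCCCC2)c2nc[nH]c2n1`) gives 60% which is the higher of the two numbers, with a gap beyond the usual scatter. Compound 3 (`COc1cc(N2CCC(C(=O)N3CCOCC3)CC2)ccc1Nc1nc(NC2CCCCC2)c2nc[nH]c2n1`) matches compound 2 except in one place, with morpholin-4-yl in place of 3-(dimethylamino)pyrrolidin-1-yl on a carbonyl carbon. Going by the values given here, no two measured compounds differ in just one place, so the data offer no direct guide to this change. The estimated step of a number 5 percentage points lower from compound 2 to compound 3 (within the scatter) is expected to stay within the usual scatter. Compound 3 is expected to give 55% with an estimated range from 35% to 75% as its likely span.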

Compound 3, percent of the compound remaining: 70%
Beside the measured number, compound 3's estimate is 15 percentage points below it; measured number inside the range.
By their numbers in this assay, from the lowest: compound 1; then compounds 2 and 3 (each within the scatter of the next).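

Compound 2 and compound 3 give the one comparison shown at this position: in this assay, morpholin-4-yl in place of 3-(dimethylamino)pyrrolidin-1-yl on a carbonyl carbon gives a number 10 percentage points higher from compound 2 to compound 3 (within the scatter). The two groups therefore cannot be told apart on this read-out, so the dimethylamino-bearing ring can be exchanged for morpholin-4-yl without the numbers parting beyond the scatter. Nothing shown explains why these two groups read alike. Still open, as far as these compounds go, is how a smaller group on the same carbonyl carbon, such as dimethylamino or a plain piperidin-1-yl ring, would read. From the compounds shown here alone, a carboxylic acid there is equally open.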